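Thiophen-2-yl in place of 4-fluorophenyl: working notes

A few compounds are considered here, and "the series" means these few. Any claim that something is new, unique, unknown or untested is made for them only; others in the source may bear on it.

In a functional assay on NCI-H460 cells (Homo sapiens) for inhibition, with a stated time of 72 h (a lower number here means a stronger inhibitor, a higher number a weaker inhibitor), compound 1 `COc1ccc(S(=O)(=O)N2CCc3cccc(-c4ccco4)c32)cc1` gives 94.5 nM and compound 2 `COc1ccc(S(=O)(=O)N2CCc3cccc(-c4ccc(F)cc4)c32)cc1` gives 95.5 nM with no difference beyond the scatter. Compound 3 `COc1ccc(S(=O)(=O)N2CCc3cccc(-c4c(F)c(F)c(F)c(F)c4F)c32)cc1` at 4760 nM lies beyond the scatter from compound 2, with the higher number. Compound 4 `COc1ccc(S(=O)(=O)N2CCc3cccc(-c4cccs4)c32)cc1` carries thiophen-2-yl in place of 4-fluorophenyl on an aromatic carbon relative to compound 2. The nearest measured step is a 1.0-fold higher number from compound 1 to compound 2 (0.00 log units; within the scatter) for 4-fluorophenyl in place of furan-2-yl on an aromatic carbon, and it stays within the scatter. Thiophen-2-yl, like furan-2-yl, is a five-membered aromatic ring with 1 hetero atom, so no step beyond the scatter is expected in this assay for compound 4. The expected step is a 1.1-fold lower number from compound 2 to compound 4 (0.03 log units; within the scatter) and lies within the scatter. For compound 4 the estimated value is 90 nM with an expected range from 40 nM to 220 nM in this series.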

Compound 4, half-maximal inhibitory concentration: 229 nM
Compound 4: middle estimate off by 2.5-fold (0.41 log units), on the low side; the measured number lies above the stated range.
By their numbers in this assay, from the lowest: compounds 1 and 2 (each within the scatter of the next); then compound 4; then compound 3.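

In this assay the earlier step between furan-2-yl and 4-fluorophenyl stayed within the scatter, but this position does not accept every aromatic ring equally: thiophen-2-yl in place of 4-fluorophenyl gives a 2.4-fold higher number from compound 2 to compound 4 (0.38 log units; beyond the scatter) as a modest loss. The five-membered rings also differ from each other, with thiophen-2-yl in place of furan-2-yl giving a 2.4-fold higher number from compound 1 to compound 4 (0.38 log units; beyond the scatter) at the same modest size. Nothing available here accounts for this difference between thiophen-2-yl and furan-2-yl.

Going by these compounds, whether thiophen-3-yl behaves like thiophen-2-yl remains open. So does the response of this position to a phenyl ring carrying an amine or a carboxylic acid.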